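A Phenyl Group Added to Compound 2

This account rests on a few compounds, and the source may have more. Where it says the series, first, only, none or still open, it means among the compounds named here.

In a functional assay on Jurkat cells (Homo sapiens) for cytotoxicity, read by luminescence and CellTiter-Glo, with a stated time of 3 days (on this read-out higher numbers stand for weaker inhibition and lower numbers for stronger inhibition), compound 2 `O=C(Nc1ccc(C(F)(F)F)cc1)c1cc(Cl)ccc1O` gives 710 nM, within the scatter of both compound 1 `N#Cc1ccc(NC(=O)c2ccc(Br)cc2O)c(Cl)c1` at 750 nM and compound 3 `O=C(Nc1ccc(C(F)(F)F)cc1)c1cc(F)ccc1O` at 580 nM. Compound 4 `O=C(Nc1ccc(C(F)(F)F)cc1)c1cc(Cl)c(-c2ccccc2)cc1O` differs from compound 2 by one change: phenyl in place of hydrogen on an aromatic carbon. For the measured compounds named here, the one measured step that bears on it is a 1.2-fold lower number from compound 2 to compound 3 (0.09 log units; within the scatter), which replaces the chloro group with fluoro and adds no phenyl, so it offers only weak guidance. Going by the values given here, no measured step shows what a phenyl does here, and no shift beyond the scatter is expected in this assay. The expected step is a 1.4-fold lower number from compound 2 to compound 4 (0.15 log units; within the scatter), a small one toward a lower number. Compound 4 is estimated at 500 nM, with an expected range of 170 nM to 1500 nM.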

Compound 4, half-maximal inhibitory concentration: 1160 nM
Compound 4: the middle estimate sits 2.3-fold (0.37 log units) below what was measured; the measured number falls inside the stated range.
By their numbers in this assay, from the lowest: compounds 3, 2, 1 and 4 (each within the scatter of the next).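

In this assay phenyl in place of hydrogen, ortho to a chloro group and meta to a hydroxy group, gives a 1.6-fold higher number from compound 2 to compound 4 (0.21 log units; within the scatter) and stays within the scatter. For the compounds shown here, this aromatic carbon, which bears hydrogen in the earlier compounds, can therefore carry a six-membered aromatic ring without a shift beyond the scatter. Nothing available explains this outcome.

Going by these compounds, whether an amine, a carboxylic acid or a methyl group on this same carbon would also stay within the scatter of compound 2 remains open. So does whether phenyl on compound 3 would give a similar step.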